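The source may hold more compounds than are shown below. What is called first, only, known or untested is meant among the compounds shown, and "the series" means these compounds.

Measured in an ADME assay on MT4 cells (Homo sapiens) for cytotoxicity, read by MTT assay, with a stated time of 96 h; on this read-out lower numbers stand for higher toxicity in this test and higher numbers for lower toxicity in this test:
Compound 1 `Cc1ccc(NCc2cn(-c3ccccc3)nc2-c2ccc(Cl)cc2)cc1`: > 100000 nM, a limit
Compound 2 `Cc1ccc(NCc2cn(-c3ccccc3)nc2-c2ccc(C(F)(F)F)cc2)cc1`: > 100000 nM, a limit
Compound 3 `Cc1ccc(NCc2cn(-c3ccccc3)nc2-c2ccc(C)cc2)cc1`: > 100000 nM, a limit

Compound 3 gives > 100000 nM, which is a limit. It has no number to rank by, and the limit of > 100000 nM in this assay, at which 3 of the 3 values shown sit, applies to the whole set.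

Compound 4 `Cc1ccc(-c2nn(-c3ccccc3)cc2CNc2ccccc2)cc1` differs from compound 3 by hydrogen in place of methyl on an aromatic carbon: 4-methylphenyl to phenyl, on the (4-methylphenyl)amino group.

The measured steps, a step that the two limits leave unreadable from compound 1 to compound 3 and a step that the two limits leave unreadable from compound 2 to compound 3, and also a step that the two limits leave unreadable from compound 1 to compound 2, concern a different group and have no readable size. No measured size therefore carries over.

Expected for this assay is a number no higher from compound 3 to compound 4 (the limit leaves the size open), meaning none beyond the scatter and no set direction.

For compound 4 the estimate is 100000 nM, with an expected range of 40000 nM to 200000 nM.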

Compound 4, half-maximal cytotoxic concentration: > 100000 nM
Compound 4 was reported as a limit; the forecaster's own chance of this, stated with the estimate: 85%; the middle value lies on the limit itself.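

Compound 3 and compound 4 give no readable step, because both sit at the same limit: the limit of > 100000 nM in this assay, at which 4 of the 4 values shown sit.

In this assay the compounds shown leave open where any half-maximal cytotoxic concentration lies, and whether these substituent changes shift it.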